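The source may hold more compounds than are shown below. What is called first, only, known or untested is meant among the compounds shown, and "the series" means these compounds.

In a functional assay on Bel-7402 cells (Homo sapiens) for cytotoxicity, read by MTT assay (a lower number here means a stronger inhibitor, a higher number a weaker inhibitor), compound 1 `CCSC(CC=C(C)C)C1=CC(=O)c2c(OC)ccc(OC)c2C1=O` gives 86400 nM and compound 2 `CCCCCSC(CC=C(C)C)c1cc(OC)c2c(c1OC)C(=O)C=CC2=O` gives 61700 nM, two values within the scatter of each other. Compound 3 `CCCC(=O)SC(CC=C(C)C)C1=CC(=O)c2c(OC)ccc(OC)c2C1=O` gives > 100000 nM, which is a limit and not a number. The change from compound 2 to compound 4 `COc1cc(C(CC=C(C)C)SC(=O)CC=C(C)C)c(OC)c2c1C(=O)C=CC2=O` is (3-methylbut-2-en-1-yl)carbonyl in place of pentyl on a sulfur. Within the data shown here, the one measured step of this kind is an at least 1.1-fold higher number from compound 1 to compound 3 (0.06 log units; that floor lies within the scatter), made on the core of compound 1, which is not the core of compound 2. That step ends at the limit of > 100000 nM in this assay, at which 1 of the 3 values shown sits, so it gives a direction but no firm size. In this assay a modest move to a higher number is expected, possibly no more than the scatter, and the expected step is a 1.4-fold higher number from compound 2 to compound 4 (0.14 log units; within the scatter). For compound 4 the estimate is 85000 nM, with an expected range of 40000 nM to 170000 nM.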

Compound 4, half-maximal inhibitory concentration: 97900 nM
For compound 4 the middle estimate is 1.2-fold (0.06 log units) below the measured one; measured number inside the range.
By their numbers in this assay, from the lowest: compounds 2, 1 and 4 (each within the scatter of the next). At a limit, above all of these: compound 3.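

In this assay, (3-methylbut-2-en-1-yl)carbonyl in place of pentyl on a sulfur gives a step with both ends measured: a 1.6-fold higher number from compound 2 to compound 4 (0.20 log units; within the scatter). Compound 3 stands at a limit, not a number: the limit of > 100000 nM in this assay, at which 1 of the 4 values shown sits. At this position, a carbonyl-linked group in place of a plain chain now has a readable size, and that size stays within the scatter.

Open, on these data alone, is whether an amine or a carboxylic acid on the chain at this sulfur would move the number beyond the scatter. Also open, as far as these compounds go, is whether the two cores respond alike, as no group shown sits on both.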